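The source may report more compounds than this note shows. Statements on the series, on what has been measured and on what is new or still open speak of the compounds shown alone.

Working notes on the series. Compound 2 `CC1=CCCC(C)(C)C1/C=C/C(=O)/C=C/c1cccc([N+](=O)[O-])c1` stands at 4700 nM in a functional assay on CWR22R cells (Homo sapiens) for cytotoxicity, read by MTT assay, with a stated time of 72 h; a higher number here means a weaker inhibitor, a lower number a stronger inhibitor. Within the data shown here, the only other measured member is compound 1 `CC1=CCCC(C)(C)C1/C=C/C(=O)/C=C/c1cccc(C(F)(F)F)c1`, which in this assay gives 2900 nM. The step of a 1.6-fold higher number from compound 1 to compound 2 (0.21 log units; within the scatter) is the whole of the measured record, and the two numbers therefore sit together rather than apart.

Compound 3 `CC1=CCCC(C)(C)C1/C=C/C(=O)/C=C/c1cccc(C)c1` differs from compound 2 in one place: methyl in place of nitro on an aromatic carbon. Of the measured steps, only a 1.6-fold higher number from compound 1 to compound 2 (0.21 log units; within the scatter) touches the same position, and it exchanged one substituent for another there without leaving the scatter. Among the measured compounds shown here, no measured step brings in a methyl at that place, so the record gives no direction for this change; it shows only that one exchange at this position did not move the number beyond the scatter.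

On that basis no step beyond the scatter is expected: a 1.2-fold lower number from compound 2 to compound 3 (0.09 log units; within the scatter) is the estimated outcome, with the result for compound 3 in this assay expected near 3800 nM, between 1500 nM and 10000 nM. For the measured compounds named here, a methyl has no precedent here, so the range is kept wide.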

Compound 3, half-maximal inhibitory concentration: 15200 nM
Estimate against measurement, compound 3: 4.0-fold (0.60 log units) below; the measured number lies above the stated range.
By their numbers in this assay, from the lowest: compounds 1 and 2 (each within the scatter of the next); then compound 3.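

In this assay this position now shows that a change here can leave the scatter: methyl in place of nitro gives a 3.2-fold higher number from compound 2 to compound 3 (0.51 log units; beyond the scatter) and methyl in place of trifluoromethyl gives a 5.2-fold higher number from compound 1 to compound 3 (0.72 log units; beyond the scatter) at the same place. Both steps are modest and run the same way, so methyl stands apart from the two groups it replaces, while those two remain within the scatter of each other and compound 3 is the weakest of the three in this read-out. The single earlier exchange at this position could not have shown this, and nothing at hand bears on what lies behind the methyl steps.

Three substituents at one place give only a small sample, and they do not establish how the number would respond to a hydroxyl, an amine, a carboxylic acid or a longer chain such as ethyl there. From the compounds shown here alone, it also remains open whether any other group would join compound 3 at the weaker end or would instead stay with compound 1 and compound 2, and whether a group could bring the number lower than theirs.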